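A few compounds are considered here, and "the series" means these few. Any claim that something is new, unique, unknown or untested is made for them only; others in the source may bear on it.

Measured compounds:
Compound 1, `CCCCCCCC/C=C\CCCCCCC(=O)c1nc2c(C)cccc2o1`: in an assay on isolated protein for inhibition of Fatty-acid amide hydrolase 1 (Homo sapiens) (a higher number here means a weaker inhibitor, a lower number a stronger inhibitor), compound 1 gives > 100000 nM, a limit of the assay and not a number.
Compound 2, `CCCCCCCC/C=C\CCCCCCC(=O)c1nc2ccc(C)cc2o1`: in this assay compound 2 gives > 100000 nM, also a limit and not a number.
Compound 3, `CCCCCCCC/C=C\CCCCCCC(=O)c1nc2ccccc2o1`: in this assay compound 3 gives 370 nM.

Among the compounds with values here, compound 3 therefore stands as the only compound with a number in this assay; the other two sit at the limit of > 100000 nM in this assay, at which 2 of the 3 values shown sit.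

Compound 4, `CCCCCCCC/C=C\CCCCCCC(=O)c1nc2cc(C)ccc2o1`, differs from compound 3 by methyl in place of hydrogen on an aromatic carbon. The two measured steps that bear on this, an at least 270-fold lower number from compound 1 to compound 3 (2.43 log units; beyond the scatter) and an at least 270-fold lower number from compound 2 to compound 3 (2.43 log units; beyond the scatter), both show that a methyl on the shared core is removed with a large drop in the number. A methyl entering at a third place on the same core is therefore expected to move compound 4 in the opposite direction, a large rise in this assay of about a 110-fold higher number from compound 3 to compound 4 (2.03 log units; beyond the scatter), with a real chance that only a limit is reported. Compound 4 is estimated at 40000 nM, range 3000 nM to 200000 nM.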

Compound 4, inhibition constant: > 100000 nM
Compound 4: a limit, no number; the forecaster's own chance of this, stated with the estimate: 55%; middle value at least 2.5-fold (0.39 log units) away from the limit.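

Methyl in place of hydrogen on this aromatic carbon, meta to a fused ring and para to a fused ring, gives an at least 270-fold higher number from compound 3 to compound 4 (2.43 log units; beyond the scatter) in this assay, so a third place on the shared core also fails to keep a measurable number. The result for compound 4 is a limit of the assay and not a number. All three methyl compounds shown now sit at the same ceiling, and only the unsubstituted compound 3 keeps a number: the limit of > 100000 nM in this assay, at which 3 of the 4 values shown sit.

These limits leave the three methyl places unranked. As far as these compounds go, whether the loss is specific to methyl also stays open, and a fluorine or methoxy group at this place could test that.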